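A few compounds are considered here, and "the series" means these few. Any claim that something is new, unique, unknown or untested is made for them only; others in the source may bear on it.

Compound 1 `CC(C)(C)C1=C(C(=O)O)N2C(=O)[C@H]([C@H](O)c3ccccc3)[C@H]2O1` gives 7 h in an ADME assay, in phosphate buffer, at 28 degrees C, at pH 7.0 (a lower number here means that the compound disappears faster, a higher number that the compound lasts longer), the lowest of the two numbers in hand. Compound 2 `CC(C)(C)C1=C(C(=O)O)N2C(=O)[C@H]([C@H](O)CCc3ccccc3)[C@H]2O1` gives 21 h in this assay; the step of a 3.0-fold higher number from compound 1 to compound 2 (0.48 log units; beyond the scatter) is the only measured one that bears on the present change. Compound 3 `CC(C)(C)C1=C(C(=O)O)N2C(=O)[C@H]([C@H](O)CCc3ccncc3)[C@H]2O1` differs from compound 1 by 2-(pyridin-4-yl)ethyl in place of phenyl on a saturated chain carbon bound to an oxygen on a saturated carbon and a saturated ring carbon. The measured step covers the chain extension but not the ring nitrogen, so an upward step of roughly the same size is expected, a 2.6-fold higher number from compound 1 to compound 3 (0.41 log units; beyond the scatter). Compound 3 is therefore estimated at 18 h in this assay, with a range from 8 h to 40 h.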

Compound 3, half-life: 13.7 h
For compound 3 the middle estimate is 1.3-fold (0.12 log units) above the measured one; measured number inside the range.
By their numbers in this assay, from the lowest: compounds 1, 3 and 2 (each within the scatter of the next, the first and the last beyond it).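

In this assay, 2-(pyridin-4-yl)ethyl in place of phenyl gives a 2.0-fold higher number from compound 1 to compound 3 (0.29 log units; within the scatter), so this change cannot be told apart from no change. With the chain held, pyridin-4-yl in place of phenyl gives a 1.5-fold lower number from compound 2 to compound 3 (0.19 log units; within the scatter), so the ring nitrogen also shows no effect that can be read at this position. No measurement in hand explains either step. Still open, going by these compounds, is whether a longer chain, or an amine in place of pyridin-4-yl, would move the half-life beyond the scatter.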